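The source may hold more compounds than are shown below. What is called first, only, known or untested is meant among the compounds shown, and "the series" means these compounds.

Measured so far:
compound 1 `C=C1C(=O)O[C@]2(C)CC[C@@H]1C[C@H](O)[C@@]1(C)CC[C@H](OC(C)=O)[C@@](C)(CCC2=O)O1` — < 20 ug/mL
compound 2 `C=C1C(=O)O[C@]2(C)CC[C@@H]1C[C@H](O)[C@@]1(C)CC[C@H](O1)[C@](C)(O)CC[C@H]2OC(C)=O` — < 20 ug/mL

Of the compounds shown here, two have been tested in a functional assay on HeLa cells (Homo sapiens) for cytotoxicity, read by MTT assay; on this read-out lower numbers stand for an effect already at smaller amounts and higher numbers for an effect only at larger amounts of compound. For compound 1 the result < 20 ug/mL is a limit of the assay and not a number. For compound 2 the result < 20 ug/mL is likewise a limit of the assay. Compound 2 therefore stands with compound 1 at the limit of < 20 ug/mL in this assay, at which 2 of the 2 values shown sit, and no order between the two can be drawn from these results. Among the compounds with values here, no step between measured compounds has been worked out, so the series itself offers nothing on the size of a change of this kind.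

The next compound, compound 3 `C=C1C(=O)O[C@]2(C)CC[C@@H]1C[C@H](OC(C)=O)[C@@]1(C)CC[C@H](O1)[C@](C)(O)CC[C@H]2OC(C)=O`, differs from compound 2 by acetyl in place of hydrogen on an oxygen on a saturated carbon. In this assay the expected step that the limit leaves unreadable from compound 2 to compound 3 is taken as small, with no direction expected beyond the scatter, and the result is expected to sit again at the limit. Compound 3 is estimated at 10 ug/mL, within 2 ug/mL to 20 ug/mL.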

Compound 3, concentration for half-maximal effect: < 20 ug/mL
Compound 3 ended at the assay's limit (the forecaster's own chance of this, stated with the estimate: 70%); the middle value does not contradict the limit.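

No step can be read from compound 2 to compound 3 in this assay, as both results are limits of the assay and not numbers: the limit of < 20 ug/mL in this assay, at which 3 of the 3 values shown sit.

The compounds shown leave open whether hydroxy to acetoxy changes the effect on these cells at all, and in which direction.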